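The source may report more compounds than this note shows. Statements on the series, on what has been measured and on what is new or still open speak of the compounds shown alone.

Working notes on the series. Among the measured compounds shown here, in a functional assay on MCF7 cells (Homo sapiens) for inhibition, with a stated time of 72 h (on this read-out higher numbers stand for weaker inhibition and lower numbers for stronger inhibition), compound 1 (`NC1CCC(Nc2nc(NCc3ccc(-c4ccccc4)nc3)c3ncn(C4CCCC4)c3n2)CC1`) gives 483 nM and compound 2 (`NC1CCC(Nc2nc(NCc3ccc(-c4ccsc4)nc3)c3ncn(C4CCCC4)c3n2)CC1`) gives 100 nM, the lower of the two numbers so far, and this gap lies beyond the scatter. The next structure is compound 3 (`NC1CCC(Nc2nc(NCc3ccc(-c4ccccc4O)nc3)c3ncn(C4CCCC4)c3n2)CC1`), which differs from compound 2 by 2-hydroxyphenyl in place of thiophen-3-yl on an aromatic carbon, next to the ring nitrogen and para to a large group.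

For the measured compounds named here, only one measured step bears on this change: a 4.8-fold lower number from compound 1 to compound 2 (0.68 log units; beyond the scatter), a modest step with thiophen-3-yl in place of phenyl. Going by the values given here, compound 3 returns to a six-membered aromatic ring of carbon only, as in compound 1, but no measured compound carries 2-hydroxyphenyl, so the effect of that group cannot be read from the data. A partial return towards compound 1 is therefore expected in this assay, meaning a higher number but a smaller step than the measured one. The expected step is a 2.2-fold higher number from compound 2 to compound 3 (0.34 log units; beyond the scatter), though its size is uncertain. For compound 3 the estimated value is 220 nM, with an expected range of 70 nM to 650 nM.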

Compound 3, half-maximal inhibitory concentration: 18 nM
For compound 3 the middle estimate is 12-fold (1.09 log units) above the measured one; the measured number lies below the stated range.
By their numbers in this assay, from the lowest: compound 3; then compound 2; then compound 1.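

In this assay the aromatic carbon next to the ring nitrogen and para to a large group proves more sensitive than the first pair suggested, with 2-hydroxyphenyl in place of thiophen-3-yl giving a 5.6-fold lower number from compound 2 to compound 3 (0.74 log units; beyond the scatter) and placing the lowest number of the series on a six-membered aromatic ring of carbon only. Hydroxy in place of hydrogen on an aromatic carbon gives a 27-fold lower number from compound 1 to compound 3 (1.43 log units; beyond the scatter) as the only large step so far, so the ring type alone does not set the number: compound 1 and compound 3 both carry that ring type yet stand at opposite ends of the order. Nothing measured here accounts for this step.

The compounds shown do not separate the contribution of the hydroxy group from that of its place on the phenyl ring, and a methoxy group or an amine in place of the hydroxy would bear on that question. On these data alone, it also remains open whether a hydroxy group on the thiophen-3-yl ring would shift the number in the same direction.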